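The source may report more compounds than this note shows. Statements on the series, on what has been measured and on what is new or still open speak of the compounds shown alone.

Compound 1 `Nc1ccc(-c2cc(=O)c3c(N)c(F)c(CO)c(F)c3o2)cc1F` serves as the starting point. In a functional assay on HeLa cells (Homo sapiens) for cytotoxicity, read by neutral red uptake, with a stated time of 3 days (on this read-out lower numbers stand for stronger inhibition and higher numbers for weaker inhibition), compound 1 gives 24000 nM. Compound 2 `[N-]=[N+]=Nc1c(F)c(N)c2c(=O)cc(-c3ccc(N)c(F)c3)oc2c1F` carries an azido group where compound 1 has a hydroxymethyl group, and in this assay compound 2 gives 1200 nM, which is a 20-fold lower number from compound 1 to compound 2 (1.30 log units; beyond the scatter). Compound 3 `CCCCCCCCCC(=O)OCc1c(F)c(N)c2c(=O)cc(-c3ccc(N)c(F)c3)oc2c1F` carries a nonylcarbonyl on the oxygen of that hydroxymethyl group. For compound 3 the result in this assay is a limit, > 100000 nM, not a number, as recorded by the limit of > 100000 nM in this assay, at which 1 of the 3 values shown sits. The step is an at least 4.1-fold higher number from compound 1 to compound 3 (0.61 log units; beyond the scatter). Among the two numbers recorded, compound 2 stands lowest, with compound 1 nearest.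

Compound 4 `CN(C)Cc1c(F)c(N)c2c(=O)cc(-c3ccc(N)c(F)c3)oc2c1F` is the next compound to be measured. Its change from compound 2 is (dimethylamino)methyl in place of azido on an aromatic carbon. Both measured steps alter the same position: the one to the azido gave a large gain, the one on the hydroxymethyl oxygen gave at least a modest loss. Going by the values given here, since compound 4 no longer holds the azido that drove the gain of compound 2, and instead holds a group seen in no measured compound, the expected outcome is a step back toward the number of compound 1, estimated as a 6.7-fold higher number from compound 2 to compound 4 (0.82 log units; beyond the scatter). Compound 4 is therefore expected to give about 8000 nM, within a range from 2000 nM to 40000 nM.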

Compound 4, half-maximal inhibitory concentration: 8900 nM
For compound 4 the middle estimate is 1.1-fold (0.05 log units) below the measured one; the measured number falls inside the stated range.
By their numbers in this assay, from the lowest: compound 2; then compound 4; then compound 1. At a limit, above all of these: compound 3.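

At the aromatic carbon ortho to two fluoro groups, exchanging azido for (dimethylamino)methyl gives up only part of the gain seen with azido: in this assay there is a 7.4-fold higher number from compound 2 to compound 4 (0.87 log units; beyond the scatter) and the result still lies on the lower side of the hydroxymethyl compound. The comparison with that compound gives a 2.7-fold lower number from compound 1 to compound 4 (0.43 log units; beyond the scatter) in the same read-out, so changing only the atom attached to the saturated carbon, dimethylamino in place of hydroxy, is enough to move the number beyond the scatter. Three groups at this one position now stand in a clear order, with azido lowest, (dimethylamino)methyl in the middle and hydroxymethyl highest, and each gap is beyond the scatter.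

Nothing measured here accounts for this order, so the data give no reason for the place of compound 4 in it. Still open, from the compounds shown here alone, is how a primary aminomethyl group, a longer chain ending in dimethylamino, or a carboxylic acid at this position would read, and whether the order of the three groups would hold on another cell line.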